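The source may report more compounds than this note shows. Statements on the series, on what has been measured and on what is new or still open speak of the compounds shown alone.

Measured so far:
- compound 1 `CCN(CC)CN1C(=O)/C(=N/NC(=S)Nc2ccccc2)c2cc(Cl)ccc21`: 40000 nM
- compound 2 `CCN(CC)CN1C(=O)/C(=N/NC(N)=S)c2cc(Cl)ccc21`: 71000 nM
- compound 3 `CCN(CC)CN1C(=O)/C(=N/NC(=S)Nc2ccc(OC)cc2)c2ccccc21`: 1900 nM

All three values come from a functional assay on CCRF-CEM cells (Homo sapiens) for inhibition, read by cell counting, with a stated time of 72 h; on this read-out lower numbers stand for stronger inhibition and higher numbers for weaker inhibition. Compound 3, at 1900 nM, has the lowest number of the three, and its gaps to the other two lie beyond the scatter. The next compound, compound 4 `CCN(CC)CN1C(=O)/C(=N/NC(=S)Nc2ccc(C)cc2)c2ccccc21`, has methyl in place of methoxy on an aromatic carbon, para to a large group: methyl in place of methoxy on an aromatic carbon.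

Within the data shown here, only one measured step is available, a 1.8-fold higher number from compound 1 to compound 2 (0.25 log units; within the scatter). It lies within the scatter, but it is a change at another place, so it bears only weakly on this one. No exchange at this aromatic carbon has been measured, and compound 3 differs from compound 1 in more than one place. As far as these compounds go, with so little evidence, no shift beyond the scatter is expected in this assay, and the direction stays open. The expected step is a 1.3-fold higher number from compound 3 to compound 4 (0.12 log units; within the scatter). For compound 4 the estimated value is 2500 nM, with an expected range from 700 nM to 9000 nM.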

Compound 4, half-maximal inhibitory concentration: 12000 nM
Beside the measured number, compound 4's estimate is 4.8-fold (0.68 log units) below it, outside the stated range (above it).
By their numbers in this assay, from the lowest: compound 3; then compound 4; then compounds 1 and 2 (each within the scatter of the next).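

In this assay, among these compounds, the change from 4-methoxyphenyl to 4-methylphenyl gives a 6.3-fold higher number from compound 3 to compound 4 (0.80 log units; beyond the scatter), the first measured exchange at this aromatic carbon, and it shows that a single-group change here can move the number beyond the scatter. Among the compounds shown here, the only earlier step, a 1.8-fold higher number from compound 1 to compound 2 (0.25 log units; within the scatter), lies at another place and did not show a shift of this kind. By count, the exchange removes one hydrogen-bond acceptor and one heavy atom, but nothing measured here explains the step or separates these two differences.

As far as these compounds go, whether an amine or a hydroxyl group on this same aromatic carbon would give a number nearer compound 3 or compound 4 remains open. Compounds 1 and 3 differ in more than one place, so the step at this aromatic carbon cannot be carried over to the core of compound 1.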